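Bromo step on the compound 3 scaffold

The source may hold more compounds than are shown below. What is called first, only, known or untested is meant among the compounds shown, and "the series" means these compounds.

Measured so far in a functional assay on MDA-MB-231 cells (Homo sapiens) for antiproliferative activity, read by sulforhodamine B assay, with a stated time of 48 h; on this read-out lower numbers stand for stronger inhibition and higher numbers for weaker inhibition
- compound 1 `COc1cc(C(=O)/C=C\Nc2ccc(-c3nc4cc(OC)c(OC)c(OC)c4s3)cc2)c(Br)c(OC)c1OC` gives 15600 nM
- compound 2 `COc1cc(OC)c2sc(-c3ccc(N/C=C\C(=O)c4cc(OC)c(OC)c(OC)c4Br)c(C)c3)nc2c1` gives 17300 nM
- compound 3 `COc1cc(OC)c2sc(-c3ccc(N/C=C\C(=O)c4cc(OC)c(OC)c(OC)c4)cc3)nc2c1` gives 15800 nM

Compound 3 at 15800 nM stands within the scatter of both compound 1 and compound 2, so the three values form one group with no order among them. Compound 4 `COc1cc(OC)c2sc(-c3ccc(N/C=C\C(=O)c4cc(OC)c(OC)c(OC)c4Br)cc3)nc2c1` has not yet been measured. The change bromo in place of hydrogen on an aromatic carbon puts bromo in place of hydrogen on an aromatic carbon, ortho to a large group and ortho to a methoxy group.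

Among the measured compounds shown here, no two measured compounds differ in one place only, so no direct step is available. Compound 1 at 15600 nM and compound 2 at 17300 nM both carry this bromo but also differ from compound 3 elsewhere, which makes them only loose guides. Their values nevertheless sit within the scatter of the value without bromo. In this assay the estimated step is a 1.0-fold higher number from compound 3 to compound 4 (0.01 log units; within the scatter) and is expected to stay within the scatter, with no direction favoured. Compound 4 is expected at 16000 nM within an estimated range of 9000 nM to 28000 nM on this read-out.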

Compound 4, half-maximal inhibitory concentration: 16100 nM
Estimate against measurement, compound 4: 1.0-fold (0.00 log units) below; the measured number falls inside the stated range.
By their numbers in this assay, from the lowest: compounds 1, 3, 4 and 2 (each within the scatter of the next).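

In this assay the bromo in place of hydrogen on an aromatic carbon, ortho to a large group and ortho to a methoxy group, can now be read as a direct single-place step, which compounds 1 and 2 could only hint at: a 1.0-fold higher number from compound 3 to compound 4 (0.01 log units; within the scatter) is what it comes to on the shared core. Compound 4 also ties the two bromo compounds into the series through single-place steps elsewhere on the molecule, with hydrogen in place of methyl giving a 1.1-fold lower number from compound 2 to compound 4 (0.03 log units; within the scatter) and hydrogen in place of methoxy giving a 1.0-fold higher number from compound 1 to compound 4 (0.01 log units; within the scatter) in this assay, so bromo, methyl and the added methoxy all stand within the scatter in these settings. No measurement of any property of these groups stands alongside the steps, so the data give no account of this outcome.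

All four compounds form one group in this assay, so the series shown gives no step beyond the scatter at this position or at the other two. Open, from the compounds shown here alone, is whether an amine, a carboxylic acid or a longer chain such as butoxy in place of the bromo would give a step beyond the scatter on this same core.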